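The source may hold more compounds than are shown below. What is called first, only, known or untested is meant among the compounds shown, and "the series" means these compounds.

Compound 2 `CCOc1ccsc1CN[C@@H]1C[C@H]2C[C@@H]([C@H]1C)C2(C)C` gives 50000 nM in an ADME assay on MDCK cells (Canis lupus familiaris) for cytotoxicity, read by microscopy, with a stated time of 48 h (on this read-out lower numbers stand for higher toxicity in this test and higher numbers for lower toxicity in this test), the higher of the two numbers shown; its nearest neighbour, compound 3 `C[C@H]1[C@H](NCc2ccc(Br)s2)C[C@H]2C[C@@H]1C2(C)C`, gives 43000 nM, a gap within the scatter. Compound 1 `C[C@H]1[C@H](NCc2cncnc2)C[C@H]2C[C@@H]1C2(C)C` reaches only the limit > 100000 nM in this assay. Compound 4 `CCCc1ccsc1CN[C@@H]1C[C@H]2C[C@@H]([C@H]1C)C2(C)C` differs from compound 2 by propyl in place of ethoxy on an aromatic carbon. Among the compounds with values here, the single measured step, an at least 2.3-fold lower number from compound 1 to compound 3 (0.36 log units; beyond the scatter), exchanges the whole aromatic group on the saturated chain carbon bound to the amine nitrogen and leaves no substituent on the five-membered aromatic ring with 1 sulfur altered, so it offers no guide to swapping ethoxy for propyl. Within the data shown here, with no measured pair mirroring this change, no step beyond the scatter is expected, a 1.3-fold lower number from compound 2 to compound 4 (0.10 log units; within the scatter). Compound 4 is therefore estimated at 40000 nM, between 15000 nM and 100000 nM.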

Compound 4, minimum cytotoxic concentration: 50000 nM
Beside the measured number, compound 4's estimate is 1.3-fold (0.10 log units) below it; the measured number falls inside the stated range.
By their numbers in this assay, from the lowest: compounds 3, 2 and 4 (each within the scatter of the next). At a limit, above all of these: compound 1.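

Propyl in place of ethoxy on this aromatic carbon, two ring bonds from the ring sulfur, gives no change at the digits printed from compound 2 to compound 4 (within the scatter) in this assay. The ethoxy oxygen, the one hydrogen-bond acceptor that leaves, is thus not required to keep this read-out where it stands, which the earlier step, an exchange of the whole aromatic group, could not show. Compound 1 alone stands at a limit rather than a number: the limit of > 100000 nM in this assay, at which 1 of the 4 values shown sits.

Going by these compounds, whether an amine, a carboxylic acid or a longer chain on this carbon would shift the number remains open.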